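The source may hold more compounds than are shown below. What is called first, only, known or untested is meant among the compounds shown, and "the series" means these compounds.

Compound 1 `COc1ccc(Nc2cc(Nc3ccc(Oc4ccncc4-c4cccnc4)c(F)c3)ncn2)cc1` gives 1010 nM in a functional assay on MKN-45 cells (Homo sapiens) for cytotoxicity, read by MTT assay, with a stated time of 72 h; on this read-out lower numbers stand for stronger inhibition and higher numbers for weaker inhibition.
Compound 2 `Fc1ccc(Nc2cc(Nc3ccc(Oc4ccncc4-c4cccnc4)c(F)c3)ncn2)cc1F` gives 80 nM in this assay.
Compound 3 `Fc1cc(Nc2cc(Nc3cccc(Cl)c3)ncn2)ccc1Oc1ccncc1-c1cccnc1` gives 30 nM in this assay.

Compound 1 stands highest of the three numbers. The step of a 13-fold lower number from compound 1 to compound 2 (1.10 log units; beyond the scatter) and the step of a 34-fold lower number from compound 1 to compound 3 (1.53 log units; beyond the scatter) are both large, and the step of a 2.7-fold lower number from compound 2 to compound 3 (0.43 log units; beyond the scatter) is modest. Compound 4 `COc1cc(Nc2cc(Nc3ccc(Oc4ccncc4-c4cccnc4)c(F)c3)ncn2)cc(OC)c1` differs from compound 1 by 3,5-dimethoxyphenyl in place of 4-methoxyphenyl on a nitrogen on an aromatic ring. Neither large step bears directly on this change: both exchanged the 4-methoxyphenyl for a halogen-bearing phenyl, whereas compound 4 keeps methoxy substitution and adds a second methoxy group. Within the data shown here, no measured step therefore supports a change beyond the scatter in this assay. Compound 4 is thus expected to give 800 nM, within 250 nM to 2500 nM, which would be a step of a 1.3-fold lower number from compound 1 to compound 4 (0.10 log units; within the scatter).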

Compound 4, half-maximal inhibitory concentration: 1750 nM
Compound 4: middle estimate off by 2.2-fold (0.34 log units), on the low side; the range from low to high includes it.
By their numbers in this assay, from the lowest: compound 3; then compound 2; then compounds 1 and 4 (each within the scatter of the next).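

In this assay, 3,5-dimethoxyphenyl in place of 4-methoxyphenyl on this nitrogen stays within the scatter (a 1.7-fold higher number from compound 1 to compound 4 (0.24 log units; within the scatter)), so the second methoxy group does not close the gap to the halogen-bearing compounds. That gap stays large for compound 4 (a 58-fold higher number from compound 3 to compound 4 (1.77 log units; beyond the scatter)) and (a 22-fold higher number from compound 2 to compound 4 (1.34 log units; beyond the scatter)), and among these four compounds both methoxy-bearing phenyl groups give higher numbers than both halogen-bearing ones. Nothing available explains this difference. The compounds shown leave open how an unsubstituted phenyl would compare, and whether an amine or a carboxylic acid on this phenyl would fall with the methoxy-bearing or the halogen-bearing compounds.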